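The source may report more compounds than this note shows. Statements on the series, on what has been measured and on what is new or still open speak of the compounds shown alone.

Measured so far:
compound 1 `Cn1cnnc1SCC(=O)N/N=c1/scc(-c2ccc([N+](=O)[O-])cc2)n1-c1ccccc1` — in a functional assay on C6 cells (Rattus norvegicus) for cytotoxicity, read by MTT assay, with a stated time of 24 h; on this read-out higher numbers stand for weaker inhibition and lower numbers for stronger inhibition: "not determined" (no result reported)
compound 2 `Cc1ccc(-c2cs/c(=N/NC(=O)CSc3nncn3C)n2-c2ccccc2)cc1` — 56 ug/mL
compound 3 `Cn1cnnc1SCC(=O)N/N=c1/scc(-c2ccc(F)cc2)n1-c1ccccc1` — "not determined" (no result reported)

Compound 1 stands without a number in this assay; no result was reported for it, and the same holds for compound 3. The only figure in hand is that of compound 2, which in this assay gives 56 ug/mL. Compound 2 shares the core of compound 1 but carries a different group on the phenyl ring, so it offers only a rough anchor for where this series sits.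

Compound 4 `Cn1nnnc1SCC(=O)N/N=c1/scc(-c2ccc([N+](=O)[O-])cc2)n1-c1ccccc1` differs from compound 1 in one place: 1-methyl-1H-tetrazol-5-yl in place of 4-methyl-4H-1,2,4-triazol-3-yl on a sulfur. Going by the values given here, no measured pair shows what this exchange does, so no direction can be read from the data; the author expects a step that stays within the scatter, or at most a modest shift in either direction. Taking compound 2 as the only anchor, compound 4 is estimated at 50 ug/mL in this assay, with a range from 15 ug/mL to 200 ug/mL.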

Compound 4, half-maximal inhibitory concentration: > 200 ug/mL
Compound 4: no number, only a limit (the forecaster's own chance of this, stated with the estimate: 30%); middle value at least 4.0-fold (0.60 log units) away from the limit.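

Going by these compounds alone, compound 1 has no number in this assay, so no step to compound 4 can be read. Compound 4 gives > 200 ug/mL, which is a limit and not a number. The compounds shown leave open what exchanging 4-methyl-4H-1,2,4-triazol-3-yl for 1-methyl-1H-tetrazol-5-yl does in this assay.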